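Methoxy in place of methylsulfonyl: notes on compound 3

A few compounds are considered here, and "the series" means these few. Any claim that something is new, unique, unknown or untested is made for them only; others in the source may bear on it.

In an ADME assay on L6 cells (Rattus norvegicus) for cytotoxicity, read by resazurin assay, with a stated time of 72 h (a lower number here means a stronger inhibitor, a higher number a weaker inhibitor), compound 1 `CC(C)c1ccc(C(=O)NC(=O)c2ccccc2O)cc1` gives 19 ug/mL. Compound 2 `CS(=O)(=O)c1ccc(C(=O)NC(=O)c2ccccc2O)cc1` gives > 100 ug/mL, which is a limit of the assay and not a number. Compound 2 therefore stands at the limit of > 100 ug/mL in this assay, at which 1 of the 2 values shown sits.

The change under review leads to compound 3 `COc1ccc(C(=O)NC(=O)c2ccccc2O)cc1`: methoxy in place of methylsulfonyl on an aromatic carbon. In words, this is methoxy in place of methylsulfonyl on an aromatic carbon, para to a large group. Going by the values given here, one measured step bears on it, at the same place: an at least 5.2-fold higher number from compound 1 to compound 2 (0.72 log units; beyond the scatter), with methylsulfonyl in place of isopropyl. Given that step from compound 1, removing methylsulfonyl is expected to move this assay towards a lower number, by a modest but uncertain amount. The expected step is an at least 2.5-fold lower number from compound 2 to compound 3 (0.39 log units; beyond the scatter). Compound 3 is estimated at 40 ug/mL, with an expected range of 15 ug/mL to 100 ug/mL.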

Compound 3, half-maximal inhibitory concentration: 39 ug/mL
For compound 3 the middle estimate is 1.0-fold (0.01 log units) above the measured one; the measured number falls inside the stated range.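

With methoxy at this position, para to a large group, this assay gives a readable number for a group other than isopropyl, and the change from methylsulfonyl gives an at least 2.5-fold lower number from compound 2 to compound 3 (0.40 log units; beyond the scatter). Methoxy also stands apart from isopropyl, with a 2.1-fold higher number from compound 1 to compound 3 (0.31 log units; beyond the scatter), so it takes a middle place among the three groups, and all three exchanges at this one position give steps beyond the scatter. Compound 2 remains a limit of the assay and not a number, so the full size of the step from methylsulfonyl stays unfixed: the limit of > 100 ug/mL in this assay, at which 1 of the 3 values shown sits.

On these data alone, three groups at one position do not establish a trend, and whether an amine, a carboxylic acid or a longer chain would fall within the same span stays open. As far as these compounds go, whether this order holds on any other core also stays open.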